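The compounds below may be only part of what the source reports. "The series", "measured", "known", "first", "only" and "open" are said of these compounds alone.

Measured so far in a functional assay on HT-29 cells (Homo sapiens) for antiproliferative activity, read by MTT assay, with a stated time of 72 h, tested at 10 uM; a lower number here means less inhibition, a higher number more inhibition at the concentration tested (going by the name of the read-out):
compound 1 `CCCC(=O)Nc1cc(Oc2ccc(Nc3nccc4[nH]cc(-c5ccc(F)cc5)c(=O)c34)cc2F)ccn1`, 23.5%
compound 2 `Cn1cc(-c2ccc(F)cc2)c(=O)c2c(Nc3ccc(Oc4ccnc(NC(=O)C5CC5)c4)c(F)c3)nccc21`, 24.8%
compound 3 `CCC(=O)Nc1cc(Oc2ccc(Nc3nccc4[nH]cc(-c5ccc(F)cc5)c(=O)c34)cc2F)ccn1`, 68.7%

Compound 2 stands second highest of the three numbers. Its nearest neighbour is compound 1, whose value lies within the scatter of that of compound 2, while compound 3 lies well beyond it. Among the measured compounds shown here, the one step measured between compounds that differ in a single place is a number 45.2 percentage points higher from compound 1 to compound 3 (beyond the scatter), a large change on the carbonyl side of the shared core. Compound 2 differs from compound 1 in two places at once, so its own number cannot be tied to a single step.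

Compound 4 `CC(C)(O)Cn1cc(-c2ccc(F)cc2)c(=O)c2c(Nc3ccc(Oc4ccnc(NC(=O)C5CC5)c4)c(F)c3)nccc21` is not yet measured. It differs from compound 2 as follows: 1-hydroxy-1-methylethyl in place of hydrogen on a saturated chain carbon bound to an aromatic nitrogen. For the measured compounds named here, no measured step touches the saturated chain carbon bound to an aromatic nitrogen; the only large step seen, from compound 1 to compound 3, sits on the carbonyl side, and that side of compound 4 is unchanged from compound 2. Nothing therefore speaks for a shift beyond the scatter in this assay, but the lack of any comparable step leaves the range wide. The expected step is a number 5.2 percentage points higher from compound 2 to compound 4 (within the scatter). Compound 4 is estimated at 30%, with a range from 8% to 62%.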

Compound 4, a percentage reported as inhibition, at one concentration (the size of the read-out at that concentration, not a potency): -2.6%
Beside the measured number, compound 4's estimate is 32.6 percentage points above it, outside the stated range (below it).
By their numbers in this assay, from the lowest: compound 4; then compounds 1 and 2 (each within the scatter of the next); then compound 3.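

In this assay, the saturated chain carbon bound to an aromatic nitrogen now has a measured step of its own: with 1-hydroxy-1-methylethyl in place of hydrogen, the reading shows a number 27.4 percentage points lower from compound 2 to compound 4 (beyond the scatter), and compound 4 gives -2.6%. Among the compounds shown here, the number therefore responds to a change at this place with the carbonyl side untouched, whereas the only earlier single-place step, a number 45.2 percentage points higher from compound 1 to compound 3 (beyond the scatter), lay on the carbonyl side. Nothing measured on these compounds accounts for the step at this new place.

From the compounds shown here alone, a single step cannot separate the contribution of the hydroxy group from that of the added carbons in the methyl to 2-hydroxy-2-methylpropyl change, and it remains open whether a chain carrying an amine or a carboxylic acid in place of 2-hydroxy-2-methylpropyl would read the same in this assay. Going by these compounds, it is also open whether the same change would lower the number on compound 3 , whose reading leaves far more room for a fall than that of compound 2 .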